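An Ethylsulfonamide in Place of a Methylpyrazole on the Shared Core

The source may report more compounds than this note shows. Statements on the series, on what has been measured and on what is new or still open speak of the compounds shown alone.

Compound 1, `Cc1n[nH]cc1-c1cccc2c1CCC2c1ncc[nH]1`: 902 nM
Compound 2, `CS(=O)(=O)Nc1cccc2c1CCC2c1ncc[nH]1`: > 10000 nM, a limit of the assay
Compound 3, `Cn1cc(-c2cccc3c2CCC3c2ncc[nH]2)cn1`: > 10000 nM, a limit of the assay

In a functional assay on CHO cells for agonist activity at Alpha-1B adrenergic receptor (Homo sapiens), read by FLIPR and calcium flux (on this read-out lower numbers stand for an effect already at smaller amounts and higher numbers for an effect only at larger amounts of compound), compound 1 gives 902 nM. Compound 2 reaches only a limit of this assay, > 10000 nM. Compound 3 likewise gives only a limit, > 10000 nM. Compound 3 therefore stands at the top of the measured range, and the limit of > 10000 nM in this assay, at which 2 of the 3 values shown sit, marks where it sits. Of the measured steps, an at least 11-fold higher number from compound 1 to compound 2 (1.04 log units; beyond the scatter) and an at least 11-fold higher number from compound 1 to compound 3 (1.04 log units; beyond the scatter) are both large losses of potency away from compound 1, while a step that the two limits leave unreadable from compound 2 to compound 3 cannot be sized, as both ends are limits.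

Compound 4, `CCS(=O)(=O)Nc1cccc2c1CCC2c1ncc[nH]1`, is the next step: (ethylsulfonyl)amino in place of 1-methyl-1H-pyrazol-4-yl on an aromatic carbon. The closest measured relative is compound 2, which carries a methanesulfonamido group at that place and shows only a limit, > 10000 nM. Going by the values given here, nothing among the measured compounds points to a recovery of potency with a sulfonamide at this position. Compound 4 is therefore expected to give about 15000 nM, within 5000 nM to 50000 nM, most likely again reported only as a limit. The expected step that the limit leaves unreadable from compound 3 to compound 4 is thus not one that should be readable.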

Compound 4, half-maximal effective concentration: > 10000 nM
Compound 4: a limit, no number; the forecaster's own chance of this, stated with the estimate: 75%; the middle value is on the limit's open side.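

In this assay compound 4 gives > 10000 nM, which is a limit of the assay and not a number. Adding one methyl to the methanesulfonamido group of compound 2, which turns it into the (ethylsulfonyl)amino group of compound 4, therefore does not bring the value back into the readable range, and placing this group where compound 1 carries its 3-methyl-1H-pyrazol-4-yl gives an at least 11-fold higher number from compound 1 to compound 4 (1.04 log units; beyond the scatter). The steps among compound 2, compound 3 and compound 4 cannot be read, which leaves compound 1 as the only one of the four with a real number and adds one more compound to those gathered at the top of the range: the limit of > 10000 nM in this assay, at which 3 of the 4 values shown sit.

On these data alone, how far beyond the limit compound 2, compound 3 and compound 4 really lie stays open, so no order among them can be given and any effect of the added methyl remains hidden. Also open, as far as these compounds go, is what a simple amine, a carboxylic acid or a longer chain such as propylsulfonylamino would do on the same aromatic carbon of the shared core.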